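Swapping a Thiazolidinedione Ring for a Hydantoin: Solubility Outlook

A few compounds are considered here, and "the series" means these few. Any claim that something is new, unique, unknown or untested is made for them only; others in the source may bear on it.

Compound 1, `CC(C)[C@@H](C[C@H]1SC(=O)NC1=O)c1ccc(-c2ccc3cccc(F)c3c2)[nH]c1=O`: 23900 nM in a physicochemical assay for solubility, in phosphate buffer, measured as kinetic solubility; on this read-out lower numbers stand for lower solubility and higher numbers for higher solubility.
Compound 2, `CC(C)C(c1ccc(-c2ccc3cccc(F)c3c2)[nH]c1=O)C1SC(=O)NC1=O`: 20100 nM in this assay.

Of the compounds shown here, two with a shared core have been measured so far. Going by the values given here, compound 2 and compound 1 differ from each other in more than one place, so no single step can be drawn between them; their two numbers sit within the usual scatter of each other, and nothing separates them on this read-out. Compound 3, `CC(C)C(c1ccc(-c2ccc3cccc(F)c3c2)[nH]c1=O)C1NC(=O)NC1=O`, has not yet been measured. It differs from compound 2 in one place only: 2,5-dioxoimidazolidin-4-yl in place of 2,4-dioxo-1,3-thiazolidin-5-yl on a saturated chain carbon bound to an aromatic carbon and a saturated chain carbon. Among the compounds with values here, no measured pair in this set shows what such a change does, so the expectation for compound 3 rests on compound 2 alone, with its 20100 nM as the anchor. The step expected from compound 2 to compound 3 is a 1.5-fold higher number from compound 2 to compound 3 (0.17 log units; within the scatter), pointing upward but of a size that may not stand clear of the scatter. The estimate for compound 3 is 30000 nM, with a range from 12000 nM to 75000 nM.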

Compound 3, solubility: 10600 nM
Compound 3: middle estimate off by 2.8-fold (0.45 log units), on the high side, and the stated range ends above it.
By their numbers in this assay, from the lowest: compounds 3, 2 and 1 (each within the scatter of the next, the first and the last beyond it).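

Going by these compounds alone, this is the first step in the set that can be read as a single change: on a saturated chain carbon bound to an aromatic carbon and a saturated chain carbon, 2,5-dioxoimidazolidin-4-yl replaces 2,4-dioxo-1,3-thiazolidin-5-yl, a swap that keeps the five-membered ring and the heavy-atom count but puts a nitrogen where the sulfur stood and alters the hydrogen-bond donor and acceptor counts. In this assay, this change gives a 1.9-fold lower number from compound 2 to compound 3 (0.28 log units; within the scatter), so even this exchange inside the ring does not move the number clear of the differences expected between repeated measurements. No supporting measurement bears on what lies behind this small step.

A single step on a single core leaves open whether the same ring swap would stay as small on a different core. It also leaves open whether a group of another kind on this carbon, such as a carboxylic acid or an open-chain amide, would produce a step that stands beyond the scatter.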